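The source may hold more compounds than are shown below. What is called first, only, known or untested is meant among the compounds shown, and "the series" means these compounds.

In a functional assay on MOLT-4 cells (Homo sapiens) for inhibition, read by MTT assay, with a stated time of 48 h (a higher number here means a weaker inhibitor, a lower number a stronger inhibitor), the entry for compound 1 (`CCOC(=O)C(=O)CC(=O)/C=C/c1cn(C=C(C)C)c2ccccc12`) reads "not determined" (no result reported) and the entry for compound 2 (`CCOC(=O)C(=O)CC(=O)/C=C/c1cn(-c2ccc(Cl)cc2)c2ccccc12`) reads "not determined" (no result reported) as well. Among the compounds with values here, compound 3 (`O=C(/C=C/c1cn(-c2ccc(Cl)cc2)c2ccccc12)CC(=O)C(=O)O`) gives 27000 nM and so holds the only number available, with no other value to rank it against. Compound 4 (`O=C(/C=C/c1cn(CC(=O)N2CCOCC2)c2ccccc12)CC(=O)C(=O)O`) has not yet been measured. Its change from compound 3 is ((morpholin-4-yl)carbonyl)methyl in place of 4-chlorophenyl on an aromatic nitrogen and amounts to ((morpholin-4-yl)carbonyl)methyl in place of 4-chlorophenyl on an aromatic nitrogen. Within the data shown here, no measured pair shows what such a swap does, so in this assay the expectation rests on compound 3 at 27000 nM alone. A step no larger than the usual scatter is expected, leaning toward weaker inhibition, and the estimated move is a 1.5-fold higher number from compound 3 to compound 4 (0.17 log units; within the scatter) with wide uncertainty around it. Compound 4 is therefore estimated at 40000 nM with an expected range from 12000 nM to 130000 nM when the measurement is made.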

Compound 4, half-maximal inhibitory concentration: > 40000 nM
Compound 4 ended at the assay's limit (the forecaster's own chance of this, stated with the estimate: 20%); the middle value lies on the limit itself.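

In this assay compound 4 gives > 40000 nM, which is a limit of the assay and not a number. Within the data shown here, putting ((morpholin-4-yl)carbonyl)methyl in place of 4-chlorophenyl on an aromatic nitrogen gives the first reading of any change at this place, an at least 1.4-fold higher number from compound 3 to compound 4 (0.17 log units; that floor lies within the scatter), and this step is only a floor, so it shows no recovery of inhibition with this group but does not fix how large the change is. The true size of the step stays unknown because the reading for compound 4 stops at the limit: the limit of > 40000 nM in this assay, at which 1 of the 4 values shown sits.

The compounds shown leave open what a plain methyl, a longer alkyl chain or an amine on that aromatic nitrogen would give in this assay. They also leave open whether an unsubstituted phenyl or a 4-fluorophenyl would read differently from 4-chlorophenyl.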